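Aryl-piperazine variants on a butynyloxy linker: all at limit

This account rests on a few compounds, and the source may have more. Where it says the series, first, only, none or still open, it means among the compounds named here.

compound 1 `COC(=O)CC/C(C)=C/Cc1c(OC)c(C)c2c(c1OCC#CCN1CCN(c3ccc(C)cc3)CC1)C(=O)OC2`: > 50000 nM
compound 2 `COC(=O)CC/C(C)=C/Cc1c(OC)c(C)c2c(c1OCC#CCN1CCN(C(c3ccccc3)c3ccccc3)CC1)C(=O)OC2`: > 50000 nM
compound 3 `COC(=O)CC/C(C)=C/Cc1c(OC)c(C)c2c(c1OCC#CCN1CCC(Cc3ccccc3)CC1)C(=O)OC2`: > 50000 nM

In a functional assay on FaDu cells (Homo sapiens) for inhibition, read by sulforhodamine B assay (on this read-out lower numbers stand for stronger inhibition and higher numbers for weaker inhibition), compound 1 gives > 50000 nM, which is a limit of the assay and not a number. Compound 2 likewise reaches only a limit in this assay, > 50000 nM. Compound 3 also gives a limit, > 50000 nM. Compound 1 therefore stands nowhere in particular among the values shown: every value is a limit, (the limit of > 50000 nM in this assay, at which 3 of the 3 values shown sit), and no order among the three can be read.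

Compound 4 `COC(=O)CC/C(C)=C/Cc1c(OC)c(C)c2c(c1OCC#CCN1CCN(c3ccccc3F)CC1)C(=O)OC2` differs from compound 1 by 2-fluorophenyl in place of 4-methylphenyl on an amine nitrogen in a ring. Within the data shown here, no step between measured compounds is available to calibrate this change. Since all three measured values sit at the limit of > 50000 nM in this assay, at which 3 of the 3 values shown sit, the expected step in this assay is a number no higher from compound 1 to compound 4 (the limit leaves the size open), none beyond the scatter. Compound 4 is expected to give 50000 nM in this assay, with a range from 20000 nM to 120000 nM, and most probably it will again be reported only as a limit.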

Compound 4, half-maximal inhibitory concentration: > 50000 nM
Compound 4: only a limit was reported; the forecaster's own chance of this, stated with the estimate: 85%; the middle value sits exactly at the limit.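

No step can be read from compound 1 to compound 4 in this assay, since both values are limits and not numbers. The compounds shown leave open whether any group on the amine nitrogen in the ring gives a readable value: the limit of > 50000 nM in this assay, at which 4 of the 4 values shown sit.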